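Lengthening a Side Chain in a Pair of Inactive Compounds

The source may hold more compounds than are shown below. What is called first, only, known or untested is meant among the compounds shown, and "the series" means these compounds.

Measured so far:
compound 1 `CCCCCc1cc2ccccc2nc1-c1cc(-c2ccccc2)no1`
compound 2 `CCCc1cc2ccccc2nc1-c1cc(-c2ccc(C)cc2)no1`

Both have been tested in a functional assay on MDA-MB-231 cells (Homo sapiens) for inhibition, read by MTT assay, with a stated time of 24 h; a lower number here means a stronger inhibitor, a higher number a weaker inhibitor. Compound 1 gives > 100000 nM, which is a limit of the assay rather than a number. Compound 2 gives > 100000 nM, again only a limit. Both measured values sit at the limit of > 100000 nM in this assay, at which 2 of the 2 values shown sit. Compound 3 `CCCCCc1cc2ccccc2nc1-c1cc(-c2ccc(C)cc2)no1` has not been measured; it differs from compound 2 by ethyl in place of hydrogen on a saturated chain carbon, three bonds along the chain from an aromatic carbon. Within the data shown here, no step between measured compounds exists, so the size of this change is unknown; with both neighbours at the limit of > 100000 nM in this assay, at which 2 of the 2 values shown sit, no move beyond the scatter is expected. Compound 3 is therefore estimated at 100000 nM (range 30000 nM to 300000 nM), an expected step of a number no higher from compound 2 to compound 3 (the limit leaves the size open).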

Compound 3, half-maximal inhibitory concentration: > 100000 nM
Compound 3: only a limit was reported (the forecaster's own chance of this, stated with the estimate: 85%); the middle value sits exactly at the limit.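

Compound 3, like compound 1 and compound 2, gives only a limit, so no step among these three compounds can be read: the limit of > 100000 nM in this assay, at which 3 of the 3 values shown sit.

Which change to the shared core, if any, would give a measurable value stays open.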